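Triazole series on HL-60: halogen swap on the phenyl ring

The compounds below may be only part of what the source reports. "The series", "measured", "known", "first", "only" and "open" are said of these compounds alone.

Measured compounds:
- compound 1 `COc1ccc(-n2ncnc2-c2cc(OC)c(OC)c(OC)c2)cc1` gives in a functional assay on HL-60 cells (Homo sapiens) for antiproliferative activity, read by MTT assay, with a stated time of 72 h (on this read-out lower numbers stand for stronger inhibition and higher numbers for weaker inhibition), 6200 nM.
- compound 2 `COc1cc(-n2ncnc2-c2ccc(F)cc2)cc(OC)c1OC` gives in this assay only a limit of the assay, > 10000 nM.
- compound 3 `COc1cc(-c2ncnn2-c2ccc([N+](=O)[O-])cc2)cc(OC)c1OC` gives in this assay only a limit of the assay, > 10000 nM.

Compound 2 therefore stands at the upper limit of this assay, without a number of its own; the limit of > 10000 nM in this assay, at which 2 of the 3 values shown sit, shows that it shares this position with a second member of the set. Compound 4 `COc1cc(-n2ncnc2-c2cccc(Cl)c2)cc(OC)c1OC` is not yet measured and differs from compound 2 as follows: 3-chlorophenyl in place of 4-fluorophenyl on an aromatic carbon.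

Among the compounds with values here, only one measured step exists, an at least 1.6-fold higher number from compound 1 to compound 3 (0.20 log units; that floor lies within the scatter), and it concerns a different part of the shared core, so it says nothing direct about a halogen swap on the phenyl ring. Within the data shown here, no measured pair in this set changes the phenyl substituent alone.

The expectation for compound 4 in this assay is therefore anchored on the limit of compound 2 and on the fact that only compound 1 has a number at all. Compound 4 is estimated at 12000 nM, with a range from 4000 nM to 40000 nM. The expected step that the limit leaves unreadable from compound 2 to compound 4 is taken as none beyond the scatter, and a limit rather than a number is the more likely outcome.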

Compound 4, half-maximal inhibitory concentration: > 10000 nM
Compound 4: a limit, no number; the forecaster's own chance of this, stated with the estimate: 65%; the middle value is on the limit's open side.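

Compound 2 and compound 4 both give only a limit of the assay in this assay, so no step can be read between them: the limit of > 10000 nM in this assay, at which 3 of the 4 values shown sit.

The compounds shown leave open whether 3-chlorophenyl in place of 4-fluorophenyl on the shared core changes the read-out at all, since neither compound has a number of its own.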